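Aryl amide in place of cyclopropyl on compound 2

The compounds below may be only part of what the source reports. "The series", "measured", "known", "first", "only" and "open" are said of these compounds alone.

Going by the values given here, compound 2 `CN1CCC(c2c[nH]c3ccc(NC(=O)C4CC4)nc23)CC1` gives 1700 nM in an assay for binding affinity to 5-hydroxytryptamine receptor 1B (Homo sapiens), read by radioligand binding (a lower number here means a stronger inhibitor, a higher number a weaker inhibitor), the highest number among the three measured members. Nearest to it is compound 3 `Cc1cccc(C(=O)Nc2ccc3[nH]cc(C4CCN(C)CC4)c3n2)c1`, which gives 1200 nM, a gap within the scatter; furthest is compound 1 `CN1CCC(c2c[nH]c3cnc(NC(=O)c4ccc(F)cc4)cc23)CC1`, which gives 80 nM on a differently arranged core, so no single-point step connects it to compound 2.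

The next compound, compound 4 `CN1CCC(c2c[nH]c3ccc(NC(=O)c4ccc(C#N)cc4)nc23)CC1`, differs from compound 2 in one place: 4-cyanophenyl in place of cyclopropyl on a carbonyl carbon.

Among the compounds with values here, one measured step bears on this change. From compound 2 to compound 3, the same cyclopropyl on the carbonyl carbon was replaced by 3-methylphenyl, and the result was a 1.4-fold lower number from compound 2 to compound 3 (0.15 log units; within the scatter). An aryl group on this carbonyl carbon of this core therefore moved the number only within the scatter. Whether the nitrile on the ring adds anything cannot be read from the measured compounds; compound 1 carries a 4-fluorophenyl but sits on another core and gives no clean comparison.

The expectation for compound 4 is a step of a 1.7-fold lower number from compound 2 to compound 4 (0.23 log units; within the scatter), that is, little or no movement beyond the scatter. Compound 4 is estimated at 1000 nM in this assay, with a range from 300 nM to 3500 nM.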

Compound 4, inhibition constant: 310 nM
For compound 4 the middle estimate is 3.2-fold (0.51 log units) above the measured one; measured number inside the range.
By their numbers in this assay, from the lowest: compound 1; then compound 4; then compounds 3 and 2 (each within the scatter of the next).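

On the shared core, the group on the carbonyl carbon does register in this assay: 4-cyanophenyl in place of cyclopropyl gives a 5.5-fold lower number from compound 2 to compound 4 (0.74 log units; beyond the scatter) with the amide otherwise unchanged, whereas the 3-methylphenyl of compound 3 stayed within the scatter of cyclopropyl. The two aryl amides also separate, with a 3.9-fold lower number from compound 3 to compound 4 (0.59 log units; beyond the scatter) on exchanging one aryl group for the other, so an aromatic ring on this carbonyl carbon does not by itself account for the step, and what the ring carries matters here. The measurements at hand offer no explanation for this difference between the 3-methylphenyl and 4-cyanophenyl groups.

Compound 3 and compound 4 differ in both the substituent and where it sits on the ring, so the step cannot yet be assigned to the nitrile itself; unsubstituted phenyl, 3-cyanophenyl and 4-methylphenyl on the carbonyl carbon would pull these two apart. Also open, on these data alone, is whether the 4-fluorophenyl of compound 1 would behave like 4-cyanophenyl on the shared core, and whether a 4-carboxyphenyl or 4-aminophenyl would hold the step.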